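The source may report more compounds than this note shows. Statements on the series, on what has been measured and on what is new or still open speak of the compounds shown alone.

In a functional assay on HL-60 cells (Homo sapiens) for inhibition, read by MTT assay, with a stated time of 72 h (a lower number here means a stronger inhibitor, a higher number a weaker inhibitor), compound 1 `Cc1nc(-c2ccc(F)cc2)c(C(=O)N2CCN(c3cccc(Cl)c3)CC2)o1` gives 40.1 nM, compound 2 `Cc1nc(-c2cccc(F)c2)c(C(=O)N2CCN(c3cccc(Cl)c3)CC2)o1` gives 33.7 nM and compound 3 `Cc1nc(-c2ccccc2)c(C(=O)N2CCN(c3cccc(C)c3C)CC2)o1` gives 35 nM. Compound 3 lies within the usual scatter of both others, so these three numbers cannot be ranked.

Compound 4 `CC(=O)c1ccc(N2CCN(C(=O)c3oc(C)nc3-c3ccccc3)CC2)cc1` has 4-acetylphenyl in place of 2,3-dimethylphenyl on an amine nitrogen in a ring, and the counted difference is 4-acetylphenyl in place of 2,3-dimethylphenyl on an amine nitrogen in a ring.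

Within the data shown here, only one measured step exists, and it bears on this change only weakly. Putting 3-fluorophenyl in place of 4-fluorophenyl gives a 1.2-fold lower number from compound 1 to compound 2 (0.08 log units; within the scatter), a change within the scatter, but it concerns a different group. No single change at the amine nitrogen has been measured, and compounds 1 and 2 differ from compound 3 in more than one place. The data therefore give no reason to expect a step beyond the scatter, although they constrain it poorly.

The expected change is a 1.4-fold higher number from compound 3 to compound 4 (0.15 log units; within the scatter), which is a small rise at most. For compound 4 the estimated value is 50 nM, with an expected range from 15 nM to 170 nM.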

Compound 4, half-maximal inhibitory concentration: "not active" (no number reported)
Compound 4 has no reported number here; the estimate stays without a comparison.
By their numbers in this assay, from the lowest: compounds 2, 3 and 1 (each within the scatter of the next).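

Among these compounds, compound 4 is reported as "not active", with no number, in this assay, so no step from compound 3 to compound 4 can be read. How far 4-acetylphenyl in place of 2,3-dimethylphenyl moves the number stays open, and nothing shown here explains this result.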